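Amide variation on the shared core: trimethoxyphenyl analogue

A few compounds are considered here, and "the series" means these few. Any claim that something is new, unique, unknown or untested is made for them only; others in the source may bear on it.

The series keeps one core and varies the group on the amide carbonyl. Compound 1 `CC(Cl)CC(=O)NC1=C(C#N)C(c2ccc(Cl)cc2Cl)C2=C(CCCC2=O)N1c1ccc(S(N)(=O)=O)cc1` carries a 2-chloropropyl there; in a functional assay on Ehrlich cells (Mus musculus) for cytotoxicity, read by trypan blue exclusion, with a stated time of 2 h, tested at 50 ug/mL (a higher number here means a stronger effect of the compound at the concentration tested, a lower number a weaker effect), compound 1 gives 55%, the second highest of the three numbers. Compound 2 `N#CC1=C(NC(=O)c2ccccc2)N(c2ccc(S(N)(=O)=O)cc2)C2=C(C(=O)CCC2)C1c1ccc(Cl)cc1Cl`, with phenyl in that place, gives 70%, and compound 3 `Cc1ccc(C(=O)NC2=C(C#N)C(c3ccc(Cl)cc3Cl)C3=C(CCCC3=O)N2c2ccc(S(N)(=O)=O)cc2)cc1`, with 4-methylphenyl, gives 40%. The two measured exchanges at the carbonyl carbon point in opposite directions: a number 15 percentage points higher from compound 1 to compound 2 (beyond the scatter), whereas a number 15 percentage points lower from compound 1 to compound 3 (beyond the scatter), and within the aromatic pair a number 30 percentage points lower from compound 2 to compound 3 (beyond the scatter).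

Compound 4 `COc1cc(C(=O)NC2=C(C#N)C(c3ccc(Cl)cc3Cl)C3=C(CCCC3=O)N2c2ccc(S(N)(=O)=O)cc2)cc(OC)c1OC` is not yet measured. Against compound 1 the change is 3,4,5-trimethoxyphenyl in place of 2-chloropropyl on a carbonyl carbon. The aryl-for-chloropropyl steps bear on it, as does the step that adds a substituent to the aromatic ring; the latter lowered the read-out and the new group carries three ring substituents. A modest step downward is therefore expected, a number 15 percentage points lower from compound 1 to compound 4 (beyond the scatter), though the opposing directions of the two aryl steps leave the range wide. Compound 4 is estimated at 40%, between 25% and 60%.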

Compound 4, a percentage reported as activity, at one concentration (the size of the read-out at that concentration, not a potency): 95%
Beside the measured number, compound 4's estimate is 55 percentage points below it, outside the stated range (above it).
By their numbers in this assay, from the lowest: compound 3; then compound 1; then compound 2; then compound 4.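

In this assay the 2-chloropropyl group is not a ceiling at the carbonyl carbon: 3,4,5-trimethoxyphenyl gives a number 40 percentage points higher from compound 1 to compound 4 (beyond the scatter) and so exceeds every other compound in the series, each by a step beyond the scatter. Substitution on the aromatic ring therefore does not simply lower the read-out, since the methyl of compound 3 went with a fall, whereas the three methoxy groups go with a number 25 percentage points higher from compound 2 to compound 4 (beyond the scatter) and with a number 55 percentage points higher from compound 3 to compound 4 (beyond the scatter) when the comparison is made against the methyl-bearing ring. Nothing at hand accounts for why these ring substituents pull in opposite directions.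

On these data alone, whether the high read-out needs all three methoxy groups remains open. Also open, as far as these compounds go, is what a phenyl carrying a single methoxy group or a hydroxyl group would give at this carbonyl carbon.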